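Hydroxy to ethoxy in the thiophen-3-yl compound

A few compounds are considered here, and "the series" means these few. Any claim that something is new, unique, unknown or untested is made for them only; others in the source may bear on it.

compound 1 (`N#Cc1c(-c2ccccc2O)cc(-c2ccc(Br)cc2)[nH]c1=O`): 21000 nM
compound 2 (`N#Cc1c(-c2ccccc2O)cc(-c2cccc(Br)c2)[nH]c1=O`): "not determined" (no result reported)
compound 3 (`N#Cc1c(-c2ccccc2O)cc(-c2ccsc2)[nH]c1=O`): 46000 nM

In a functional assay on HT-29 cells (Homo sapiens) for cytotoxicity, with a stated time of 72 h (on this read-out higher numbers stand for weaker inhibition and lower numbers for stronger inhibition), compound 3 gives 46000 nM as the higher of the two numbers available. Compound 2 adds no number to the comparison. For the measured compounds named here, the only measured step (a 2.2-fold higher number from compound 1 to compound 3 (0.34 log units; beyond the scatter)) puts thiophen-3-yl in place of 4-bromophenyl on an aromatic carbon, and it is modest, though beyond the scatter.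

Compound 4 (`CCOc1ccccc1-c1cc(-c2ccsc2)[nH]c(=O)c1C#N`) differs from compound 3 by ethyl in place of hydrogen on an oxygen on an aromatic ring (ethyl in place of hydrogen, hydroxy to ethoxy) on an oxygen on an aromatic ring. Going by the values given here, no measured step touches this oxygen, so the step to compound 3 (a 2.2-fold higher number from compound 1 to compound 3 (0.34 log units; beyond the scatter)) serves only as a rough guide to size and says nothing about direction. A modest shift towards a lower number in this assay is tentatively expected, and it may not clear the scatter. The estimated change is a 1.5-fold lower number from compound 3 to compound 4 (0.19 log units; within the scatter) and remains uncertain in direction. For compound 4 the expected value is 30000 nM with an estimated range of 8000 nM to 100000 nM for the measurement.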

Compound 4, half-maximal inhibitory concentration: 1250 nM
Estimate against measurement, compound 4: 24-fold (1.38 log units) above, outside the stated range (below it).
By their numbers in this assay, from the lowest: compound 4; then compound 1; then compound 3.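

Ethyl on the oxygen is the first change at this position, and in this assay it gives a 37-fold lower number from compound 3 to compound 4 (1.57 log units; beyond the scatter) as a large step. A free hydroxy on this aromatic ring is therefore not required for activity on this read-out, at least with thiophen-3-yl in the compound. This one change also far outweighs the exchange of 4-bromophenyl for thiophen-3-yl (a 2.2-fold higher number from compound 1 to compound 3 (0.34 log units; beyond the scatter)), and no measured evidence bears on the origin of the gain.

On these data alone, whether ethyl on this oxygen has a similar effect in compound 1, which carries 4-bromophenyl, remains open, so the step cannot yet be called general. Also open, as far as these compounds go, is how methyl, a longer chain such as propyl, or a chain ending in an amine would read on the same oxygen.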